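Working notes on a pyridine-amide series, aryl variation

A few compounds are considered here, and "the series" means these few. Any claim that something is new, unique, unknown or untested is made for them only; others in the source may bear on it.

Measured so far:
- compound 1, `Cc1cccc(-c2ccnc(C(=O)Nc3ccc(Oc4ccnc5[nH]ccc45)cc3)c2)c1`, gives 7010 nM in a functional assay on A549 cells (Homo sapiens) for cytotoxicity, read by MTT assay, with a stated time of 72 h; on this read-out lower numbers stand for stronger inhibition and higher numbers for weaker inhibition
- compound 2, `Cc1cccc(-c2ccnc(C(=O)Nc3ccc(Oc4ccnc5[nH]ccc45)c(F)c3)c2)c1`, gives 1750 nM in this assay

Compound 2 holds the lowest of the two numbers in this assay. For the measured compounds named here, its nearest neighbour is compound 1, and the single measured step, a 4.0-fold lower number from compound 1 to compound 2 (0.60 log units; beyond the scatter), is fluoro in place of hydrogen on an aromatic carbon.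

Compound 3, `Cc1ccc(-c2ccnc(C(=O)Nc3ccc(Oc4ccnc5[nH]ccc45)c(F)c3)c2)c(C)c1`, differs from compound 2 by 2,4-dimethylphenyl in place of 3-methylphenyl on an aromatic carbon. Going by the values given here, no measured pair alters this aryl group; the only step known, a 4.0-fold lower number from compound 1 to compound 2 (0.60 log units; beyond the scatter), concerns a different position and does not inform the present change. With nothing in the data to support a shift in either direction, the working assumption is that compound 3 stays close to compound 2 in this assay. For compound 3 the expected step is no change at the digits printed from compound 2 to compound 3 (within the scatter), within the scatter. From the compounds shown here alone, compound 3 is therefore estimated at 1750 nM in this assay, with a range from 550 nM to 5500 nM reflecting that the change is untested.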

Compound 3, half-maximal inhibitory concentration: 4350 nM
The estimate for compound 3 lay 2.5-fold (0.40 log units) below the measured number; the measured number falls inside the stated range.
By their numbers in this assay, from the lowest: compound 2; then compounds 3 and 1 (each within the scatter of the next).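

This position, opposite the ring nitrogen, proves sensitive to the aryl group it carries: in this assay, 2,4-dimethylphenyl in place of 3-methylphenyl gives a 2.5-fold higher number from compound 2 to compound 3 (0.40 log units; beyond the scatter). The aryl group is thus a second place in the series where one change moves the number beyond the scatter, alongside the fluoro change with a 4.0-fold lower number from compound 1 to compound 2 (0.60 log units; beyond the scatter), and here the direction is towards weaker inhibition. The entering group has 8 heavy atoms against 7, with one carbon-only aromatic ring and 0 hydrogen-bond donors or acceptors in both, and nothing available accounts for the step.

The two aryl groups differ in both the number of methyl groups and their placement, and the compounds shown do not separate these two differences. Also open, from the compounds shown here alone, is how this position would respond to a plain phenyl, a methoxy group, an amine or a carboxylic acid on the aryl ring, and whether the fluoro step carries over to aryl groups other than 3-methylphenyl.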